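A few compounds are considered here, and "the series" means these few. Any claim that something is new, unique, unknown or untested is made for them only; others in the source may bear on it.

Measured compounds so far:
- compound 1 `COC(=O)c1c(Nc2ccc(C)cc2)sc(C(=O)c2ccc(C)cc2)c1C`, in a functional assay, with a stated time of 150 min, tested at 15 ug/mL (on this read-out higher numbers stand for a stronger effect at the one concentration tested and lower numbers for a weaker effect), compound 1 gives "not active" (no number reported)
- compound 2 `COc1ccc(C(=O)c2sc(Nc3ccc(C)cc3)c(C(=O)O)c2C)cc1`, in this assay compound 2 gives "not active" (no number reported)
- compound 3 `Cc1ccc(C(=O)c2sc(Nc3ccccc3)c(C(=O)O)c2C)cc1`, in this assay compound 3 gives 1.25%

For the measured compounds named here, compound 3 is the only member of the series with a number attached; compound 1 and compound 2 come with no figure at all, so no step between measured compounds can be stated. Where compound 3 stands is therefore simply the one value shown, which is small for a read-out of this kind and sits within the usual scatter of zero.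

Compound 4 `Cc1ccc(Nc2sc(C(=O)c3ccc(C)cc3)c(C)c2C(=O)O)cc1` is the next entry to be measured in this assay. Its difference from compound 3 is methyl in place of hydrogen on an aromatic carbon of a six-membered aromatic ring of carbon only. Nothing in the measured set shows what such a change does here, since compound 1 and compound 2 carry no number. The step from compound 3 to compound 4 is expected to be small, with no direction established beyond the scatter, a number 0.8 percentage points higher from compound 3 to compound 4 (within the scatter). Compound 4 is accordingly estimated at 2%, within -6% to 10%.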

Compound 4, a percentage reported as activity, at one concentration (the size of the read-out at that concentration, not a potency): "not active" (no number reported)
For compound 4 the study gives words and no number, so the estimate cannot be set against anything.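

In this assay, for the compounds shown here, compound 4 gives "not active" (no number reported) and so no step from compound 3 to it can be read. No measurement shown bears on a cause. With a number on compound 3 alone, the compounds shown leave open what phenyl to 4-methylphenyl does to this read-out.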